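Positional shift of chlorine on the carboxyphenyl terminus

This account rests on a few compounds, and the source may have more. Where it says the series, first, only, none or still open, it means among the compounds named here.

Measured so far:
compound 1 `COc1cc(C(=O)O)ccc1OCCCCOc1ccc(C(=O)CC(C)(C)C)c(O)c1C` — 109%
compound 2 `Cc1c(OCCCCOc2ccc(C(=O)O)cc2Cl)ccc(C(=O)CC2CCCC2)c1O` — 27.4%
compound 3 `Cc1c(OCCCCOc2ccc(C(=O)CC(C)(C)C)c(O)c2C)cccc1C(=O)O` — 109%

In an assay on HEK293 cells for positive allosteric modulation of metabotropic glutamate receptor 3 (Rattus norvegicus), read by thallium flux, with a stated time of 2.5 min (a lower number here means a smaller maximal response, a higher number a larger maximal response), compound 2 gives 27.4%, the lowest of the three numbers. Its nearest neighbour, compound 1, gives 109%; compound 3 gives 109%. Both gaps to compound 2 lie well beyond the scatter, but compound 1 and compound 3 differ from compound 2 in more than one place, so no single-change step can be read from them.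

Compound 4 `Cc1c(OCCCCOc2ccc(C(=O)O)c(Cl)c2)ccc(C(=O)CC2CCCC2)c1O` is not yet measured. It differs from compound 2 in one place: 4-carboxy-3-chlorophenyl in place of 4-carboxy-2-chlorophenyl on an oxygen on a saturated carbon. Both keep the cyclopentyl-bearing ketone and the shared core. For the measured compounds named here, with no measured step of this kind, the direction is open; an expected step in this assay is of moderate size, more likely upward than downward, though a result within the scatter of compound 2 cannot be excluded. The maximal response of compound 4 is estimated at 45%, range 15% to 90%, which means an expected step of a number 17.6 percentage points higher from compound 2 to compound 4 (beyond the scatter).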

Compound 4, largest response reached (reported as percent of maximum), in percent of the reference or control that the assay uses: 40%
For compound 4 the middle estimate is 5 percentage points above the measured one, within the range that was stated.
By their numbers in this assay, from the lowest: compound 2; then compound 4; then compounds 1 and 3 (each within the scatter of the next).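

For the compounds shown here, this is the only single-change step so far, and it isolates the chlorine on the carboxyphenyl terminus, since the cyclopentyl-bearing ketone, the shared core and the atom count stay the same. In this assay, 4-carboxy-3-chlorophenyl in place of 4-carboxy-2-chlorophenyl gives a number 12.6 percentage points higher from compound 2 to compound 4 (beyond the scatter), so the placement of the chlorine alone moves the maximal response, though only modestly. Nothing available bears on why this placement changes the response.

Still open, on these data alone, is whether a bromine or a nitrile in place of the chlorine on the 4-carboxy-3-chlorophenyl group would shift the maximal response further in either direction. Also open, as far as these compounds go, is whether the same move of the chlorine gives a step of similar size with a ketone other than the cyclopentyl-bearing one.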